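The source may hold more compounds than are shown below. What is called first, only, known or untested is meant among the compounds shown, and "the series" means these compounds.

Compound 2 `O=C(O)CSc1cccc(NC(=O)CN2N=C(C3CCCCC3)c3ccccc3N(CC(=O)C3CCCC3)C2=O)c1` gives 1.48 nM in a functional assay on stomach for antagonist activity at Gastrin/cholecystokinin type B receptor (Rattus norvegicus) (a lower number here means tighter binding, a higher number weaker binding), the lowest of the three numbers in hand. Nearest to it stands compound 3 `CC(C)(C)C(=O)CN1C(=O)N(CC(=O)Nc2cccc(-c3nn[nH]n3)c2)N=C(C2CCCCC2)c2ccccc21` at 7.76 nM, furthest compound 1 `CC(C)(C)C(=O)CN1C(=O)N(CC(=O)Nc2cccc(-c3nc(=O)o[nH]3)c2)N=C(C2CCCCC2)c2ccccc21` at 9.55 nM; both gaps lie beyond the scatter, so compound 2 is the tightest binder measured. Compound 4 `O=C(CN1N=C(C2CCCCC2)c2ccccc2N(CC(=O)C2CCCC2)C1=O)Nc1cccc(C(=O)O)c1` differs from compound 2 by carboxy in place of (carboxymethyl)sulfanyl on an aromatic carbon. For the measured compounds named here, no measured step covers this change; the only single-point step known, a 1.2-fold lower number from compound 1 to compound 3 (0.09 log units; within the scatter), swaps one acidic ring for another and stays within the scatter, which suggests that this acidic end tolerates variation. A moderate step toward weaker binding is therefore expected, a 2.7-fold higher number from compound 2 to compound 4 (0.43 log units; beyond the scatter), since compound 2 already sits low at 1.48 nM. Compound 4 is estimated at 4 nM, with a range from 1.5 nM to 12 nM.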

Compound 4, dissociation constant: 1.95 nM
Beside the measured number, compound 4's estimate is 2.1-fold (0.31 log units) above it; low and high end bracket the measured number.
By their numbers in this assay, from the lowest: compounds 2 and 4 (each within the scatter of the next); then compounds 3 and 1 (each within the scatter of the next).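

In this assay, a 1.3-fold higher number from compound 2 to compound 4 (0.12 log units; within the scatter) follows when carboxy replaces (carboxymethyl)sulfanyl on the aromatic carbon meta to a large group. For the compounds shown here, the earlier step compared only two ring groups, whereas this one shows that carboxy and (carboxymethyl)sulfanyl, neither of which has a ring, read the same at this position. No available measurement explains why the two groups read alike. The compounds shown leave open whether the carboxylic acid is needed here at all, which an amine or a methyl ester in its place would test. They also leave open how a longer chain, such as carboxyethyl, would read.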